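Replacing 2-Chloro-4-fluorophenyl with Thiophen-2-yl in Compound 1

A few compounds are considered here, and "the series" means these few. Any claim that something is new, unique, unknown or untested is made for them only; others in the source may bear on it.

Compound 1 `COc1cc2c(Oc3ccc(NC(=O)N/N=C/c4ccc(F)cc4Cl)cc3F)ccnc2cc1OCCCN1CCCCC1` was tested in a functional assay on HT-29 cells (Homo sapiens) for cytotoxicity, read by MTT assay, with a stated time of 72 h (a higher number here means a weaker inhibitor, a lower number a stronger inhibitor), where compound 1 gives 260 nM, the lowest of the two numbers in hand. Going by the values given here, its only measured neighbour is compound 2 `COc1cc2c(Oc3ccc(NC(=O)N/N=C/c4ccc(O)cc4)cc3F)ccnc2cc1OCCCN1CCCCC1`, which in this assay gives 470 nM; the step of a 1.8-fold higher number from compound 1 to compound 2 (0.26 log units; within the scatter) stays within the usual scatter of repeated measurements. The unmeasured compound 3 `COc1cc2c(Oc3ccc(NC(=O)N/N=C/c4cccs4)cc3F)ccnc2cc1OCCCN1CCCCC1` differs from compound 1 in one place: thiophen-2-yl in place of 2-chloro-4-fluorophenyl on a carbon with a double bond to nitrogen. Among the compounds with values here, the only measured step that bears on this change is the one from compound 1 to compound 2, where exchanging the ring at the same place moved the number only within the scatter. Within the data shown here, no measured step involves thiophen-2-yl itself, so nothing points to a large shift in either direction. For compound 3 the expected step is a 1.3-fold higher number from compound 1 to compound 3 (0.13 log units; within the scatter). The estimate for compound 3 is 350 nM, with a range from 150 nM to 900 nM.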

Compound 3, half-maximal inhibitory concentration: 770 nM
The estimate for compound 3 lay 2.2-fold (0.34 log units) below the measured number, within the range that was stated.
By their numbers in this assay, from the lowest: compounds 1, 2 and 3 (each within the scatter of the next, the first and the last beyond it).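

In this assay, going by these compounds alone, the ring on this carbon can matter: thiophen-2-yl in place of 2-chloro-4-fluorophenyl gives a 3.0-fold higher number from compound 1 to compound 3 (0.47 log units; beyond the scatter) and is the first step here to pass beyond the scatter. Exchanging 4-hydroxyphenyl for thiophen-2-yl gives a 1.6-fold higher number from compound 2 to compound 3 (0.21 log units; within the scatter) and stays within the scatter, so compound 2 cannot be separated from either of the other two, and only compound 1 and compound 3 stand apart. No evidence is available to explain the difference between compound 1 and compound 3.

On these data alone, this change swaps the ring type and removes both chlorine and fluorine at once, so their separate contributions remain unknown. A plain phenyl ring or a furan-2-yl ring on this carbon would help to separate them.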